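Removing the Aromatic Chloro Group in a Cellular Inhibition Series

The source may hold more compounds than are shown below. What is called first, only, known or untested is meant among the compounds shown, and "the series" means these compounds.

Measured compounds:
compound 1, `O=C(CC(CC(=O)NC1Cc2ccccc2C1)c1ccc(Cl)cc1)NCCN1CCCC1`, 77300 nM
compound 2, `O=C(CC(CC(=O)NC1Cc2ccccc2C1)c1ccccc1)NCCN1CCCC1`, which reaches only the limit > 100000 nM, a limit and not a number
compound 3, `CCNCCNC(=O)CC(CC(=O)N(CC)C1Cc2ccccc2C1)c1ccc(Cl)cc1`, 40500 nM

All three were tested in a functional assay on HeLa cells (Homo sapiens) for inhibition; on this read-out higher numbers stand for weaker inhibition and lower numbers for stronger inhibition. Compound 1 and compound 2 share a core and differ only by hydrogen in place of chloro on an aromatic carbon; this change gave an at least 1.2-fold higher number from compound 1 to compound 2 (0.11 log units; that floor lies within the scatter), the floor arising because compound 2 sits at the limit of > 100000 nM in this assay, at which 1 of the 3 values shown sits. Compound 3 stands on a different core; the difference between the two cores is not broken down here. Compound 4, `CCNCCNC(=O)CC(CC(=O)N(CC)C1Cc2ccccc2C1)c1ccccc1`, has not yet been measured. It differs from compound 3 by hydrogen in place of chloro on an aromatic carbon, the same change as between compound 1 and compound 2. Because that earlier change gave an at least 1.2-fold higher number from compound 1 to compound 2 (0.11 log units; that floor lies within the scatter), a step of similar direction, a 2.0-fold higher number from compound 3 to compound 4 (0.30 log units; within the scatter), is expected here. Compound 4 is therefore estimated at 80000 nM, with a range from 35000 nM to 200000 nM, and a limit may again be reported.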

Compound 4, half-maximal inhibitory concentration: > 100000 nM
Compound 4: no number, only a limit; the forecaster's own chance of this, stated with the estimate: 35%; middle value at least 1.2-fold (0.09 log units) away from the limit.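

In this assay compound 4 gives > 100000 nM as a limit of the assay and not a number. Going from 4-chlorophenyl to phenyl on the core of compound 3 gave an at least 2.4-fold higher number from compound 3 to compound 4 (0.39 log units; beyond the scatter) and so weaker inhibition on that core, while on the core of compound 1 the floor of the step stays within the scatter. The change thus gives no stronger inhibition on either core, but the data do not show that it carries over with the same size: the same change on two cores in this assay, an at least 1.2-fold higher number (0.11 log units; that floor lies within the scatter) from compound 1 to compound 2 and an at least 2.4-fold higher number (0.39 log units; beyond the scatter) from compound 3 to compound 4; the limit leaves it open whether they differ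

The compounds shown leave open how large either step truly is. They also leave open whether a fluoro, bromo or methoxy group in place of chloro would keep the inhibition seen with chloro.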